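The compounds below may be only part of what the source reports. "The series", "measured", "known", "first", "only" and "open" are said of these compounds alone.

Working notes on the series. Two compounds have numbers in a functional assay on CHO-K1 cells for agonist activity at G-protein coupled receptor 6 (Homo sapiens), read by TR-FRET and cAMP accumulation, with a stated time of 20 h; a higher number here means that more compound is needed for the effect, a lower number that less compound is needed. Compound 1 `COC(=O)N1C=Cc2nc(N3CCC(Oc4ccc(F)cc4F)CC3)c(NC(C)C)nc2C1` gives 158000 nM in this assay. Compound 2 `CC(=O)N1C=Cc2nc(N3CCC(Oc4ccc(F)cc4F)CC3)c(NC3CC3)nc2C1` gives 43000 nM in this assay; on these two numbers compound 2 stands lowest, with compound 1 showing the higher value by a gap beyond the scatter. Compound 1 and compound 2 differ in two places, so nothing separates the two changes.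

Compound 3 `CC(=O)N1C=Cc2nc(N3CCC(Oc4ccc(F)cc4F)CC3)c(NC(C)C)nc2C1` is the next member and is not yet measured in this assay. Compound 3 differs from compound 2 in one place: isopropyl in place of cyclopropyl on a nitrogen on an aromatic ring. Compound 3 shares the acetyl group with compound 2 and the isopropylamino group with compound 1. For the measured compounds named here, no single-change step is known here, so the expected step from compound 2 to compound 3 is set from the two measured numbers, expected at a 1.9-fold higher number from compound 2 to compound 3 (0.27 log units; within the scatter), a loss of potency. For compound 3 the estimate in this assay is 80000 nM, expected to fall between 25000 nM and 250000 nM.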

Compound 3, half-maximal effective concentration: 34000 nM
Compound 3: the middle estimate sits 2.4-fold (0.37 log units) above what was measured; measured number inside the range.
By their numbers in this assay, from the lowest: compounds 3 and 2 (each within the scatter of the next); then compound 1.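

In this assay, isopropyl in place of cyclopropyl on a nitrogen on an aromatic ring gives a 1.3-fold lower number from compound 2 to compound 3 (0.10 log units; within the scatter), so with the acetyl group held, this exchange of an open group for a three-membered ring does not register as a difference. With the isopropylamino group held, methyl in place of methoxy on a carbonyl carbon gives a 4.6-fold lower number from compound 1 to compound 3 (0.67 log units; beyond the scatter), and of the two single changes now readable, only this one lies beyond the scatter. For the compounds shown here, nothing measured so far accounts for either step.

Still open, as far as these compounds go, is how the nitrogen tolerates groups other than these two, such as a cyclobutyl group, a longer chain or a hydroxyethyl group. From the compounds shown here alone, it is equally open whether an ethyl group or a dimethylamino group on the carbonyl carbon would follow the methyl or the methoxy result.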